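Working notes: aryl swap at the fused core, cytotoxicity

The source may report more compounds than this note shows. Statements on the series, on what has been measured and on what is new or still open speak of the compounds shown alone.

Measured compounds:
compound 1 `O=[N+]([O-])c1c(CS(=O)(=O)c2ccccc2)nc2c(-c3ccc(Cl)cc3)cc(Cl)cn12` — > 3900 nM
compound 2 `O=[N+]([O-])c1c(CS(=O)(=O)c2ccccc2)nc2c(-c3ccc(F)cc3)cc(Cl)cn12` — > 15600 nM
compound 3 `O=[N+]([O-])c1c(CS(=O)(=O)c2ccccc2)nc2c(-c3ccc(C(F)(F)F)cc3)cc(Cl)cn12` — > 3900 nM

In an ADME assay on HepG2 cells (Homo sapiens) for cytotoxicity, read by MTT assay, with a stated time of 72 h (on this read-out lower numbers stand for higher toxicity in this test and higher numbers for lower toxicity in this test), compound 1 stands at a limit of the assay, not a number. Compound 2 also stands at a limit. Compound 3 also stands at a limit. The three values fall at the limit of > 3900 nM in this assay, at which 2 of the 3 values shown sit, and at the limit of > 15600 nM in this assay, at which 1 of the 3 values shown sits. The steps a step that the two limits leave unreadable from compound 1 to compound 2, a step that the two limits leave unreadable from compound 1 to compound 3 and a step that the two limits leave unreadable from compound 2 to compound 3 therefore give no readable size and no direction.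

Compound 4 `O=[N+]([O-])c1c(CS(=O)(=O)c2ccccc2)nc2c(-c3cccs3)cc(Cl)cn12` differs from compound 1 by thiophen-2-yl in place of 4-chlorophenyl on an aromatic carbon. Among the compounds with values here, no measured step covers this kind of change, and the measured ones are unreadable, so no step beyond the scatter is expected in this assay. Compound 4 is estimated at 8000 nM, in the range 3000 nM to 25000 nM. The expected step is a step that the limit leaves unreadable from compound 1 to compound 4, most likely again reported only as a limit.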

Compound 4, half-maximal cytotoxic concentration: > 3900 nM
Compound 4: a limit, no number; the forecaster's own chance of this, stated with the estimate: 70%; the middle value does not contradict the limit.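

In this assay compound 4 gives > 3900 nM, a limit and not a number. None of the steps from compound 1, compound 2 or compound 3 to compound 4 can be read. The compounds shown leave open the actual half-maximal cytotoxic concentration of all four compounds, and with it any ranking among the aryl groups.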